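Lengthening the alkenyl chain on a sulfur-linked ester

A few compounds are considered here, and "the series" means these few. Any claim that something is new, unique, unknown or untested is made for them only; others in the source may bear on it.

Compound 1 `C=CCSC[C@H](NC(=O)c1cc(O)cc(O)c1)C(=O)OC` gives 58500 nM in an assay on RAW264.7 cells for antagonist activity at Toll-like receptor 2 (Mus musculus), read by Griess assay, with a stated time of 24 h; on this read-out lower numbers stand for stronger inhibition and higher numbers for weaker inhibition.
Compound 2 `C=CCCSC[C@H](NC(=O)c1cc(O)cc(O)c1)C(=O)OC` gives 35800 nM in this assay.

Of the compounds shown here, two have been measured so far, and they differ only in the length of the alkenyl chain on the sulfur. Compound 2 shows the lower of the two numbers, but its gap to compound 1 is small: a 1.6-fold lower number from compound 1 to compound 2 (0.21 log units; within the scatter). Since that gap sits within the scatter of repeated measurements, the two compounds cannot be told apart on these numbers alone.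

Compound 3 `C=CCCCSC[C@H](NC(=O)c1cc(O)cc(O)c1)C(=O)OC` has not yet been measured. It continues the same kind of change: allyl in place of vinyl on a saturated chain carbon, two bonds along the chain from a sulfur. Among the measured compounds shown here, the only measured step that bears on this is the one from compound 1 to compound 2, which stayed within the scatter. Adding one more chain carbon in the same way is therefore expected to give, at most, a modest change in this assay, and quite possibly none beyond the scatter.

Compound 3 is thus estimated at 30000 nM, with a range from 12000 nM to 75000 nM, meaning an expected step of a 1.2-fold lower number from compound 2 to compound 3 (0.08 log units; within the scatter).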

Compound 3, half-maximal inhibitory concentration: 57800 nM
Compound 3: middle estimate off by 1.9-fold (0.28 log units), on the low side; the measured number falls inside the stated range.
By their numbers in this assay, from the lowest: compounds 2, 3 and 1 (each within the scatter of the next).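

Among the compounds shown here, with the third chain length, the single step seen earlier gains a continuation, and no direction emerges. In this assay, going from but-3-en-1-yl to pent-4-en-1-yl on the sulfur gives a 1.6-fold higher number from compound 2 to compound 3 (0.21 log units; within the scatter), while the wider comparison of allyl with pent-4-en-1-yl gives a 1.0-fold lower number from compound 1 to compound 3 (0.01 log units; within the scatter). So all three chain lengths stay within the scatter of one another, and this position tolerates the added chain carbons without any readable trend in either direction, though nothing available explains why these chains read alike.

These compounds all carry a chain ending in a carbon-carbon double bond, so they cannot show whether a saturated propyl or butyl chain on the sulfur, or a much longer chain such as octyl, would read any differently. As far as these compounds go, they also share the methyl ester and the dihydroxyphenyl amide, so it remains open whether a carboxylic acid in place of that ester, or an amine at the end of the sulfur chain, would move the number beyond the scatter.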